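Compound 4: fluoro for carbamoyl, expected cytotoxicity

The source may hold more compounds than are shown below. What is called first, only, known or untested is meant among the compounds shown, and "the series" means these compounds.

Measured in an ADME assay on LLC-MK2 cells (Macaca mulatta) for cytotoxicity, read by spectrophotometry and crystal violet staining, with a stated time of 4 days; on this read-out higher numbers stand for lower toxicity in this test and lower numbers for higher toxicity in this test:
- compound 1 `CC(C)n1ncc2c(C(=O)Nc3cccc(C(N)=O)c3)cc(-c3cccs3)nc21`: 25000 nM
- compound 2 `CC(C)n1ncc2c(C(=O)Nc3ccccn3)cc(-c3ccccc3)nc21`: 12500 nM
- compound 3 `CC(C)n1ccc2c(C(=O)Nc3ccccn3)cc(-c3cccs3)nc21`: > 200000 nM (a limit, not a number)

Compound 2 lies within the usual scatter of compound 1, which reads 25000 nM. The reading for compound 3 is a limit: the limit of > 200000 nM in this assay, at which 1 of the 3 values shown sits.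

Compound 4 `CC(C)n1ncc2c(C(=O)Nc3cccc(F)c3)cc(-c3cccs3)nc21` keeps the core of compound 1 and carries fluoro in place of carbamoyl on an aromatic carbon, meta to a large group: fluoro in place of carbamoyl on an aromatic carbon. For the measured compounds named here, no measured pair isolates this change, so no step beyond the scatter is expected in this assay, and the estimate stays anchored on compound 1 at 25000 nM. The estimated change is a 1.2-fold higher number from compound 1 to compound 4 (0.08 log units; within the scatter). Compound 4 is expected at 30000 nM, with an estimated range of 8000 nM to 110000 nM.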

Compound 4, half-maximal cytotoxic concentration: > 200000 nM
Compound 4: a limit, no number; the forecaster's own chance of this, stated with the estimate: 10%; at least 6.6-fold (0.82 log units) between middle value and limit.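

On the core of compound 1, fluoro in place of carbamoyl on an aromatic carbon gives, in this assay, an at least 8.0-fold higher number from compound 1 to compound 4 (0.90 log units; beyond the scatter). For the compounds shown here, this is the first measured pair that isolates a change at this place, and it shows that the read-out responds to the group carried there. The reading of compound 4 is a limit, not a number, so the step has no upper end: the limit of > 200000 nM in this assay, at which 2 of the 4 values shown sit.

As far as these compounds go, whether the step belongs to the loss of carbamoyl or to fluoro itself stays open. An amine, a methoxy or a carboxylic acid on the same carbon would help separate the two.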